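This account rests on a few compounds, and the source may have more. Where it says the series, first, only, none or still open, it means among the compounds named here.

Measured in a functional assay on T98G cells (Homo sapiens) for inhibition, read by MTT assay, with a stated time of 72 h; on this read-out lower numbers stand for stronger inhibition and higher numbers for weaker inhibition:
- Compound 1 (`CC1(C)CC(NC(=S)Nc2cccc(C#N)c2)c2cc(F)ccc2O1`): 39000 nM
- Compound 2 (`CC1(C)CC(NC(=S)Nc2cccc([N+](=O)[O-])c2)c2cc(Br)ccc2O1`): 4000 nM
- Compound 3 (`CC1(C)CC(NC(=S)Nc2cccc(Cl)c2)c2cc(Br)ccc2O1`): 9000 nM

Compound 2 at 4000 nM has the lowest number of the three in this assay and thus shows the strongest inhibition of the set. Compound 4 (`CC1(C)CC(NC(=S)Nc2cccc([N+](=O)[O-])c2)c2cc(F)ccc2O1`) has not yet been measured. It differs from compound 2 as follows: fluoro in place of bromo on an aromatic carbon.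

Going by the values given here, no measured step isolates this change. The only one available, a 2.3-fold higher number from compound 2 to compound 3 (0.35 log units; beyond the scatter) (chloro in place of nitro on an aromatic carbon), is modest and lies at a different place in the molecule. Among the compounds with values here, compound 1 is the only measured compound with fluoro, and at 39000 nM it sits well above compound 2, but it also carries a nitrile instead of a nitro group. Only part of that gap can therefore be expected to carry over to compound 4.

The expected step is a 3.0-fold higher number from compound 2 to compound 4 (0.48 log units; beyond the scatter) in the direction of weaker inhibition. In this assay compound 4 is estimated at 12000 nM (expected range 4000 nM to 35000 nM).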

Compound 4, half-maximal inhibitory concentration: 9000 nM
Compound 4: middle estimate off by 1.3-fold (0.12 log units), on the high side; low and high end bracket the measured number.
By their numbers in this assay, from the lowest: compound 2; then compounds 3 and 4 (each within the scatter of the next); then compound 1.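

In this assay, the halogen place now has a step of its own, read with the nitro group held constant: fluoro in place of bromo on this aromatic carbon gives a 2.3-fold higher number from compound 2 to compound 4 (0.35 log units; beyond the scatter) and so weakens inhibition beyond the scatter. With fluoro held constant, nitro in place of cyano on an aromatic carbon gives a 4.3-fold lower number from compound 1 to compound 4 (0.64 log units; beyond the scatter), which shows that the distance of compound 1 from compound 2 is shared between the two changes and does not belong to fluoro alone. Nothing at hand explains either step.

Going by these compounds, whether a methoxy group or an amine on this same aromatic carbon would keep or lose inhibition remains open. So does whether fluoro in place of bromo would give a step of similar size alongside the chloro group of compound 3.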